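A Methyl on the Piperidine Ring: Does It Matter?

This account rests on a few compounds, and the source may have more. Where it says the series, first, only, none or still open, it means among the compounds named here.

In a functional assay on HT-29 cells (Homo sapiens) for inhibition, read by MTT assay, with a stated time of 48 h (on this read-out higher numbers stand for weaker inhibition and lower numbers for stronger inhibition), compound 1 `CN1C(=O)CN(C2CCCC2)c2nc(Nc3ccc(N4CCCCC4)cn3)ncc21` gives 12500 nM, and compound 2 `CC1CCN(c2ccc(Nc3ncc4c(n3)N(C3CCCC3)CC(=O)N4C)nc2)CC1` gives 11300 nM. The change between them is methyl in place of hydrogen on a saturated ring carbon, and the resulting step is a 1.1-fold lower number from compound 1 to compound 2 (0.04 log units; within the scatter). Compound 3 `CCN1C(=O)CN(C2CCCC2)c2nc(Nc3ccc(N4CCCCC4)cc3)ncc21` has a different core; the difference between the two cores is not broken down here. In this assay compound 3 reaches only a limit, > 30000 nM, as noted in the limit of > 30000 nM in this assay, at which 1 of the 3 values shown sits. Compound 4 `CCN1C(=O)CN(C2CCCC2)c2nc(Nc3ccc(N4CCC(C)CC4)cc3)ncc21` carries the same change as compound 2, namely (methyl in place of hydrogen on a saturated ring carbon), on the core of compound 3. Because a 1.1-fold lower number from compound 1 to compound 2 (0.04 log units; within the scatter) sat within the scatter, the step that the limit leaves unreadable from compound 3 to compound 4 is expected to be equally small. For compound 4 the estimated value is therefore 40000 nM, between 15000 nM and 100000 nM, with a real chance of another limit.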

Compound 4, half-maximal inhibitory concentration: 24400 nM
Compound 4: the middle estimate sits 1.6-fold (0.21 log units) above what was measured; the measured number falls inside the stated range.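

In this assay, the change from piperidin-1-yl to 4-methylpiperidin-1-yl gives an at least 1.2-fold lower number from compound 3 to compound 4 (0.08 log units; that floor lies within the scatter). Compound 3 reads only as a limit, > 30000 nM, and not as a true number. The result fits a small effect of the methyl on both cores, but it does not show that the change carries over from one core to the other with the same size: the same change on two cores in this assay, a 1.1-fold lower number (0.04 log units; within the scatter) from compound 1 to compound 2 and an at least 1.2-fold lower number (0.08 log units; that floor lies within the scatter) from compound 3 to compound 4; the limit leaves it open whether they differ

The compounds shown leave open what an ethyl group, a hydroxyl group or an amine would do in place of the methyl, on the same saturated ring carbon three ring bonds from the ring nitrogen. They also leave open how a methyl would behave on any other carbon of this ring.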